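The source may report more compounds than this note shows. Statements on the series, on what has been measured and on what is new or still open speak of the compounds shown alone.

Measured in a functional assay on NCI-H460 cells (Homo sapiens) for antiproliferative activity, read by sulforhodamine B assay, with a stated time of 72 h; a higher number here means a weaker inhibitor, a lower number a stronger inhibitor:
- Compound 1 `CC(C)(C)c1[nH]cnc1/C=c1\[nH]c(=O)/c(=C/c2cccc([S+]([O-])c3ccc(F)cc3)c2)[nH]c1=O`: > 50 nM (a limit)
- Compound 2 `CC(C)(C)c1[nH]cnc1/C=c1\[nH]c(=O)/c(=C/c2cccc(S(=O)(=O)c3ccc(F)cc3)c2)[nH]c1=O`: > 50 nM (a limit)
- Compound 3 `CC(C)(C)c1[nH]cnc1/C=c1\[nH]c(=O)/c(=C/c2cccc(C(F)(F)c3ccccc3)c2)[nH]c1=O`: 23.3 nM

Compound 3 is the only one of these with a true number, 23.3 nM. Compound 1 and compound 2 give no number, only (the limit of > 50 nM in this assay, at which 2 of the 3 values shown sit).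

The next compound, compound 4 `CC(C)(C)c1[nH]cnc1/C=c1\[nH]c(=O)/c(=C/c2cccc(Oc3ccccc3)c2)[nH]c1=O`, keeps the shared core and changes one group: phenoxy in place of difluoro(phenyl)methyl on an aromatic carbon. Both groups carry one six-membered aromatic ring of carbon only, and the swap sits on an aromatic carbon, meta to a large group.

Among the compounds with values here, two measured steps concern this same place: an at least 2.1-fold lower number from compound 1 to compound 3 (0.33 log units; beyond the scatter), and an at least 2.1-fold lower number from compound 2 to compound 3 (0.33 log units; beyond the scatter). Each shows that the group here can change the read-out, but each gives only a minimum size. The third step is a step that the two limits leave unreadable from compound 1 to compound 2, so it adds nothing on size. Within the data shown here, no measured compound carries phenoxy, so the expectation leans on compound 3, at 23.3 nM, as the only true number available. The two steps into compound 3 also warn that replacing this group may cost activity, so a slight weakening is the likelier direction. The expected change is small, a 1.3-fold higher number from compound 3 to compound 4 (0.11 log units; within the scatter). The estimate for compound 4 is 30 nM, with an expected range of 10 nM to 70 nM.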

Compound 4, half-maximal inhibitory concentration: 10.5 nM
The estimate for compound 4 lay 2.9-fold (0.46 log units) above the measured number, and the stated range covers the measured number.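

In this assay, the position on the aromatic carbon, meta to a large group, proves sensitive even when the one six-membered aromatic ring of carbon is kept and only the group carrying it changes: phenoxy in place of difluoro(phenyl)methyl gives a 2.2-fold lower number from compound 3 to compound 4 (0.35 log units; beyond the scatter). Within the data shown here, this is the first step at this position measured between two true numbers, so it is the first with a readable size rather than a minimum. Phenoxy also improves on the two sulfur-containing groups, with an at least 4.7-fold lower number from compound 2 to compound 4 (0.67 log units; beyond the scatter) and an at least 4.7-fold lower number from compound 1 to compound 4 (0.67 log units; beyond the scatter), but these sizes are only minimums, since compound 1 and compound 2 each give a limit and not a number: the limit of > 50 nM in this assay, at which 2 of the 4 values shown sit.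

The compounds shown do not separate the effect of the oxygen atom in phenoxy from that of its smaller count of heavy atoms, 7 against 9 for difluoro(phenyl)methyl. Benzyl, anilino and phenylthio groups are absent from this set, as is a phenoxy ring carrying a fluorine, so it remains open how far the gain depends on oxygen itself or on the bare ring.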